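Chloro scan on the phenyl tetrazole: meta position

The source may hold more compounds than are shown below. What is called first, only, known or untested is meant among the compounds shown, and "the series" means these compounds.

Measured compounds in an in vitro functional assay on 1321-N1 cells for antagonist activity at P2X purinoceptor 7 (Homo sapiens), read by FLIPR and calcium flux; on this read-out lower numbers stand for stronger inhibition and higher numbers for weaker inhibition:
compound 1 `Cc1noc(C)c1Cn1nnnc1-c1cccc(Cl)c1Cl`: 158 nM
compound 2 `c1ccc(-c2nnnn2Cc2cccnc2)cc1`: 25100 nM
compound 3 `Clc1ccccc1-c1nnnn1Cc1cccnc1`: 15800 nM

Compound 2 carries the unsubstituted phenyl ring and stands at the high end of the three numbers in this assay; compound 3 sits within the scatter of it, while compound 1, with two chlorines on that ring and a different group on the tetrazole nitrogen, gives a number far below. Going by the values given here, no single-change step links compound 1 to compound 2, so that gap is only what the two values show.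

Compound 4 `Clc1cccc(-c2nnnn2Cc2cccnc2)c1` is the next single-point change from compound 2: chloro in place of hydrogen on an aromatic carbon. Among the compounds with values here, the one measured step of the same kind is a 1.6-fold lower number from compound 2 to compound 3 (0.20 log units; within the scatter), which adds a chlorine to the same ring at another position and leaves the number inside the usual scatter. On that basis the expected step in this assay is small; a modest move to a lower number seems plausible given the low value of compound 1 with its two chlorines, but the evidence is indirect. The expected step is a 2.5-fold lower number from compound 2 to compound 4 (0.40 log units; beyond the scatter). Compound 4 is expected to give about 10000 nM, within a range of 3000 nM to 30000 nM.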

Compound 4, half-maximal inhibitory concentration: 7940 nM
Beside the measured number, compound 4's estimate is 1.3-fold (0.10 log units) above it; the measured number falls inside the stated range.
By their numbers in this assay, from the lowest: compound 1; then compounds 4, 3 and 2 (each within the scatter of the next, the first and the last beyond it).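

Working notes: in this assay, chloro on an aromatic carbon meta to a large group gives the only single-change step in this series printed as beyond the scatter, though still a modest one (a 3.2-fold lower number from compound 2 to compound 4 (0.50 log units; beyond the scatter)). The chloro step at the other position stays within the scatter (a 1.6-fold lower number from compound 2 to compound 3 (0.20 log units; within the scatter)), yet compounds 3 and 4 lie within the scatter of each other, so the two positions cannot be ranked on these numbers. No supporting measurement bears on why this single chlorine shifts the number.

The compounds shown leave open whether another group at this position, such as methoxy, trifluoromethyl or nitrile, would give a larger step than chloro. Going by these compounds alone, they also leave open how much of the low value of compound 1, at 158 nM, comes from its two chlorines and how much from the different group on its tetrazole nitrogen, since no single-change step connects it to the rest of the series.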